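Ring methyl removal in a pyridinyl aminopyridine series

A few compounds are considered here, and "the series" means these few. Any claim that something is new, unique, unknown or untested is made for them only; others in the source may bear on it.

Measured compounds and values in an assay on isolated protein for inhibition of AP2-associated protein kinase 1 (Homo sapiens), with a stated time of 3 h, in the presence of a further agent that is not named here; a higher number here means a weaker inhibitor, a lower number a stronger inhibitor:
compound 1 `Cc1cc(-c2cc(C)c(OC[C@@](C)(N)CC(C)C)cn2)ccn1`: 19 nM
compound 2 `CC(=O)Nc1cc(-c2ccc(OC[C@@H](N)CC(C)C)c(Cl)c2)ccn1`: 0.5 nM
compound 3 `COC(=O)Nc1cc(-c2cnc(OC[C@@](C)(N)CC(C)C)cc2C)ccn1`: 490 nM

Compound 3 stands at the highest number of the three, and its gaps to compound 1 and to compound 2 both lie beyond the scatter, so it is the weakest inhibitor of this set in this assay. Compound 2 gives the lowest number, and compound 1 sits between the two.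

The next compound, compound 4 `COC(=O)Nc1cc(-c2ccc(OC[C@@](C)(N)CC(C)C)nc2)ccn1`, keeps the carbamate, the shared core and the (2-amino-2,4-dimethylpentyl)oxy group of compound 3 and differs from it in one place: hydrogen in place of methyl on an aromatic carbon. The change is the loss of the methyl ortho to the large group, with nothing entering but hydrogen.

Within the data shown here, no pair of measured compounds differing in one place is available, so no step can be read off directly. Compound 1 and compound 3 both carry the ring methyl and both stand well above compound 2, which lacks it, but the three also differ elsewhere, so this is not a clean pattern. The expectation is a modest step downward, a 3.3-fold lower number from compound 3 to compound 4 (0.51 log units; beyond the scatter), for compound 4. Compound 4 is estimated at 150 nM in this assay, with a range from 40 nM to 600 nM.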

Compound 4, half-maximal inhibitory concentration: 28 nM
Estimate against measurement, compound 4: 5.4-fold (0.73 log units) above, outside the stated range (below it).
By their numbers in this assay, from the lowest: compound 2; then compounds 1 and 4 (each within the scatter of the next); then compound 3.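

In this assay, hydrogen in place of methyl on this aromatic carbon, ortho to a large group and opposite the ring nitrogen, gives an 18-fold lower number from compound 3 to compound 4 (1.24 log units; beyond the scatter). Among these compounds, this is the first step that can be read at a single place, and it shows that with the carbamate and the (2-amino-2,4-dimethylpentyl)oxy group held fixed, the loss of one methyl is enough to move the number well beyond the scatter. Nothing measured here bears on why this methyl carries such a penalty.

Going by these compounds, whether the position accepts any group other than hydrogen, such as fluorine, chlorine or methoxy, remains open. Also open, on these data alone, is whether the same step appears when an acetamide replaces the carbamate.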